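Swapping the piperidinyl end for dimethylamino on the chain

The source may hold more compounds than are shown below. What is called first, only, known or untested is meant among the compounds shown, and "the series" means these compounds.

For the measured compounds named here, in a functional assay on MDA-MB-231 cells (Homo sapiens) for cytotoxicity, read by MTT assay, with a stated time of 72 h (a higher number here means a weaker inhibitor, a lower number a stronger inhibitor), compound 2 `O=C1c2c[n+]([O-])c3ccccc3c2C(=O)c2c1c1ccccc1n2CCN1CCCCC1` gives 1050 nM as the lower of two numbers so far, while compound 1 `CCCN1CCN(CCCCn2c3c(c4ccccc42)C(=O)c2c[n+]([O-])c4ccccc4c2C3=O)CC1` gives 2980 nM and sits higher. Compound 3 `CN(C)CCCCn1c2c(c3ccccc31)C(=O)c1c[n+]([O-])c3ccccc3c1C2=O` keeps the shared core and alters only the side chain: 2-(dimethylamino)ethyl in place of piperidin-1-yl on a saturated chain carbon, two bonds along the chain from an aromatic nitrogen and the ring of the piperidin-1-yl group is gone. Read one bond further out, this is 2-(piperidin-1-yl)ethyl to 4-(dimethylamino)butyl. Going by the values given here, the one measured step at this place is a 2.8-fold lower number from compound 1 to compound 2 (0.45 log units; beyond the scatter) and it counts as modest, though it involves a different pair of groups. On that single guide, a step no larger than modest is expected, with a slight rise the more likely direction. The expected change in this assay is a 1.4-fold higher number from compound 2 to compound 3 (0.15 log units; within the scatter) and this remains only an estimate. For compound 3 the expected value is 1500 nM within a range of 500 nM to 4000 nM as an estimate only.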

Compound 3, half-maximal inhibitory concentration: 350 nM
For compound 3 the middle estimate is 4.3-fold (0.63 log units) above the measured one; measured number below the stated range.
By their numbers in this assay, from the lowest: compound 3; then compound 2; then compound 1.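

In this assay, a side chain without a ring at its end now gives the lowest number of the three, with a 3.0-fold lower number from compound 2 to compound 3 (0.48 log units; beyond the scatter). The clearest reading comes from compound 1 and compound 3, which share the same chain length and differ only in the end group: dimethylamino in place of 4-propylpiperazin-1-yl gives an 8.5-fold lower number from compound 1 to compound 3 (0.93 log units; beyond the scatter). No measurement shown here explains why these side chains differ.

On these data alone, the step between compound 2 and compound 3 changes both the chain length and the end group, so the share of each remains unknown. Piperidin-1-yl on a butyl chain, or dimethylamino on an ethyl chain, would separate the two, while diethylamino or a pyrrolidin-1-yl end would test how far the trend at this position extends.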